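Nitro to methyl swap on two cores: lipophilicity notes

The source may hold more compounds than are shown below. What is called first, only, known or untested is meant among the compounds shown, and "the series" means these compounds.

Compound 1 `Nc1nc(N)nc(-c2ccccc2[N+](=O)[O-])n1` and compound 2 `Nc1nc(N)nc(-c2ccc([N+](=O)[O-])cc2)n1` are built from the same atoms joined differently; the difference between the two cores is not broken down here. In a physicochemical assay for lipophilicity (on this read-out lower numbers stand for lower lipophilicity and higher numbers for higher lipophilicity), compound 1 gives 0.49, while compound 2 gives 1.6, the highest of the three measured numbers and beyond the scatter from both others. Compound 3 `Cc1ccccc1-c1nc(N)nc(N)n1` is compound 1 with methyl in place of nitro on an aromatic carbon, and in this assay compound 3 gives 1.26. Among the measured compounds shown here, the resulting step, a number 0.77 log units higher from compound 1 to compound 3 (beyond the scatter), is the only measured instance of this change in the set.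

Compound 4 `Cc1ccc(-c2nc(N)nc(N)n2)cc1` has not been measured. It stands to compound 2 as compound 3 stands to compound 1, with methyl in place of nitro on an aromatic carbon. The two changes are the same kind of change rather than the same one: in compound 1 the nitro sits ortho to a group of 8 heavy atoms, whereas in compound 2 it sits para to a group of 8 heavy atoms, so the measured step is carried over with some caution.

The expectation rests on a number 0.77 log units higher from compound 1 to compound 3 (beyond the scatter) applied to compound 2 at 1.6. Compound 4 is expected to give 2.3 in this assay, most likely between 1.9 and 2.7. The step is expected to be a number 0.70 log units higher from compound 2 to compound 4 (beyond the scatter), close to the earlier one, with the spread widened since the change has been seen once and at a different place.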

Compound 4, partition coefficient: 1.92
The estimate for compound 4 lay 0.38 log units above the measured number; the range from low to high includes it.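

In this assay the swap of nitro for methyl on an aromatic carbon gives a number 0.32 log units higher from compound 2 to compound 4 (beyond the scatter) and so runs the same way as a number 0.77 log units higher from compound 1 to compound 3 (beyond the scatter) on the other core, with the new step the smaller of the two. The direction therefore held in both available pairs, and neither goes against it, but the size did not carry over, so a step read on one core is a guide to sign rather than a figure to transfer to the other. Two pairs do not establish a rule for the series, and the data offer no account of why the two steps differ in size.

The compounds shown leave open whether the same direction would appear with an amine or a carboxylic acid in the place of nitro on either core, since the only replacing group here is methyl. They also leave open how a longer chain, such as ethyl or propyl, would compare with methyl in this assay and whether its step would likewise depend on the core that carries it.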